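Methyl to methoxy on the sulfonamide aryl ring

The source may hold more compounds than are shown below. What is called first, only, known or untested is meant among the compounds shown, and "the series" means these compounds.

Measured so far:
compound 1 `Cc1ccc(S(=O)(=O)Nc2nc(-c3cccc([N+](=O)[O-])c3)cs2)cc1` gives 33.4 umol/kg
compound 2 `COc1ccc(S(=O)(=O)Nc2nc(-c3cc(C(F)(F)F)ccc3F)cs2)cc1OC` gives 5.3 umol/kg

In an assay on liver for inhibition of kynurenine 3-monooxygenase (Rattus norvegicus) (a higher number here means that more compound is needed for the effect, a lower number that less compound is needed), compound 1 gives 33.4 umol/kg, the highest of the two numbers in hand. Compound 2 gives 5.3 umol/kg, a gap that lies beyond the usual scatter. Compound 2 differs from compound 1 in more than one place, so the two numbers show only that a lower dose has been reached within this series, not which change accounts for it.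

Compound 3 `COc1ccc(S(=O)(=O)Nc2nc(-c3cccc([N+](=O)[O-])c3)cs2)cc1` keeps the core of compound 1 and alters one group: methoxy in place of methyl on an aromatic carbon. Among the compounds with values here, no measured pair isolates this change. The step from compound 1 to compound 3 is expected to be small, toward a lower number if anything, and could fall within the scatter. Compound 2 also carries methoxy groups and gives 5.3 umol/kg, which weakly supports a lower number for compound 3, but its other differences leave the direction uncertain.

Compound 3 is expected to give about 20 umol/kg, with a range from 8 umol/kg to 50 umol/kg. This estimate means a step of a 1.7-fold lower number from compound 1 to compound 3 (0.22 log units; within the scatter).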

Compound 3, dose for half-maximal effect: 9 umol/kg
Compound 3: the middle estimate sits 2.2-fold (0.35 log units) above what was measured, and the stated range covers the measured number.
By their numbers in this assay, from the lowest: compounds 2 and 3 (each within the scatter of the next); then compound 1.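

In this assay, within the data shown here, there is a 3.7-fold lower number from compound 1 to compound 3 (0.57 log units; beyond the scatter) with nothing altered except 4-methylphenyl to 4-methoxyphenyl, the first change that can be read on its own. The position para to a large group therefore responds to the group it carries, and the number falls beyond the scatter with the rest of the core of compound 1 held fixed. A lower number in this series thus does not depend on changes elsewhere in the molecule, although this rests on a single pair and a modest step, and nothing in hand bears on the reason for it.

Still open, from the compounds shown here alone, is whether the effect is particular to methoxy or also appears with a longer chain such as ethoxy, or with a hydroxyl group, a chlorine atom or a dimethylamino group at the same place. Also open, going by these compounds, is whether the same change gives a step of similar size on a different core, since compound 2 differs from both compound 1 and compound 3 in more than one place and cannot answer this.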